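The source may report more compounds than this note shows. Statements on the series, on what has been measured and on what is new or still open speak of the compounds shown alone.

Measured so far:
- compound 1, `COc1cc(NC(C)CCCN2C(=O)CN(C(=O)[C@@H](C)N)C2(C)C)c2ncccc2c1`, with 120000 ug/mL in a physicochemical assay for solubility; a lower number here means a less soluble compound, a higher number a more soluble compound
- compound 2, `COc1cc(NC(C)CCCN2C(=O)[C@@H](C)NC2(C)C)c2ncccc2c1`, with 29800 ug/mL in this assay

Of the two numbers, compound 1 holds the higher one; the gap to compound 2 lies beyond the scatter. Compound 3, `COc1cc(NC(C)CCCN2C(=O)CN(C(=O)CN)C2(C)C)c2ncccc2c1`, has not been measured. It differs from compound 1 by hydrogen in place of methyl on a saturated chain carbon bound to an amine nitrogen and a carbonyl carbon. For the measured compounds named here, no step between measured compounds is available for this change. The account expects no shift beyond the scatter in this assay, with a 1.1-fold higher number from compound 1 to compound 3 (0.03 log units; within the scatter) as the estimated step. Compound 3 is therefore estimated at 130000 ug/mL, within 60000 ug/mL to 260000 ug/mL.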

Compound 3, solubility: 150000 ug/mL
Compound 3: middle estimate off by 1.2-fold (0.06 log units), on the low side; measured number inside the range.
By their numbers in this assay, from the lowest: compound 2; then compounds 1 and 3 (each within the scatter of the next).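

In this assay, hydrogen in place of methyl on the saturated chain carbon bound to an amine nitrogen and a carbonyl carbon, which turns 1-aminoethyl into aminomethyl, gives a 1.3-fold higher number from compound 1 to compound 3 (0.10 log units; within the scatter), so this change leaves the number within the scatter. The earlier compounds shown here held no step at this position, and this reading rests on a single pair. Nothing available explains the result.

From the compounds shown here alone, it remains open whether an isopropyl or phenyl group on this carbon, or a carboxylic acid in place of the amine, would move the number in this assay beyond the scatter.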